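Swapping the Piperazine Substituent: Cyclohexyl to tert-Butoxycarbonyl

A few compounds are considered here, and "the series" means these few. Any claim that something is new, unique, unknown or untested is made for them only; others in the source may bear on it.

Measured compounds:
Compound 1 `O=C(Nc1cccc(NC(=O)c2ccccn2)c1)NC1CCCCC1`: 6260 nM
Compound 2 `CN1CCN(C(=S)SCC(=O)Nc2cccc(NC(=O)c3ccccn3)c2)CC1`: 1340 nM
Compound 3 `O=C(CSC(=S)N1CCN(C2CCCCC2)CC1)Nc1cccc(NC(=O)c2ccccn2)c1`: 390 nM

In a functional assay on A549 cells (Homo sapiens) for antiproliferative activity, read by MTT assay, with a stated time of 48 h (a lower number here means a stronger inhibitor, a higher number a weaker inhibitor), compound 1 gives 6260 nM, compound 2 gives 1340 nM, and compound 3 gives 390 nM. Compound 3 has the lowest number of the three; its nearest neighbour is compound 2, and compound 1 lies furthest from it. Within the data shown here, the only single-point step among the measured compounds is a 3.4-fold lower number from compound 2 to compound 3 (0.54 log units; beyond the scatter).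

Compound 4 `CC(C)(C)OC(=O)N1CCN(C(=S)SCC(=O)Nc2cccc(NC(=O)c3ccccn3)c2)CC1` is not yet measured. It differs from compound 3 in one place: tert-butoxycarbonyl in place of cyclohexyl on an amine nitrogen in a ring. Among the measured compounds shown here, the step that bears on this change is the one from compound 2 to compound 3, where the same ring nitrogen carried methyl and then cyclohexyl; that step was modest and went toward a lower number. tert-Butoxycarbonyl is neither of those groups, and no measured pair shows it directly. A number between those of compound 2 and compound 3 is therefore expected, leaning toward the weaker side. The estimated step is a 2.3-fold higher number from compound 3 to compound 4 (0.36 log units; beyond the scatter). For compound 4 the estimate in this assay is 900 nM, with a range from 300 nM to 3000 nM.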

Compound 4, half-maximal inhibitory concentration: 180 nM
The estimate for compound 4 lay 5.0-fold (0.70 log units) above the measured number, and the stated range ends above it.
By their numbers in this assay, from the lowest: compound 4; then compound 3; then compound 2; then compound 1.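

In this assay, the amine nitrogen in a ring tolerates a substituent with no ring at all: replacing cyclohexyl with tert-butoxycarbonyl, which brings oxygen and a carbonyl, gives a 2.2-fold lower number from compound 3 to compound 4 (0.34 log units; beyond the scatter). The lower number therefore does not depend on the six-membered ring of carbon only that cyclohexyl brought to this position. Taken from methyl, the new group gives a 7.4-fold lower number from compound 2 to compound 4 (0.87 log units; beyond the scatter), a larger step than the one cyclohexyl gave, a 3.4-fold lower number from compound 2 to compound 3 (0.54 log units; beyond the scatter), so among the three groups on this nitrogen, methyl stands at the highest number and tert-butoxycarbonyl at the lowest, though nothing shown accounts for that order.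

The compounds shown leave open whether the lower number belongs to the carbonyl or to the tert-butyl part of the new group, a question that an acetyl group and a tert-butyl group placed directly on the nitrogen would separate. They also leave open how this position behaves with a bare amine hydrogen on the ring nitrogen, or with a benzyl group there.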